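Moving the methoxy group around the ring of compound 2

The source may report more compounds than this note shows. Statements on the series, on what has been measured and on what is new or still open speak of the compounds shown alone.

Measured compounds:
compound 1 `COC(OC)C1=C(C(=O)OC/C=C/c2ccc(F)cc2)C(c2cccc(Cl)c2)C(C(=O)O)=C(C)N1` — 2000 nM
compound 2 `COc1ccccc1/C=C/COC(=O)C1=C(C(OC)OC)NC(C)=C(C(=O)O)C1c1cccc(Cl)c1` — 5900 nM

In an assay on thoracic aorta for inhibition of Voltage-gated L-type calcium channel (Rattus norvegicus) (on this read-out lower numbers stand for stronger inhibition and higher numbers for weaker inhibition), compound 1 gives 2000 nM, while compound 2 gives 5900 nM, the higher of the two numbers. Among the measured compounds shown here, the only measured step is a 3.0-fold higher number from compound 1 to compound 2 (0.47 log units; beyond the scatter), where a 2-methoxyphenyl replaced a 4-fluorophenyl on a double-bonded chain carbon bound to a double-bonded chain carbon.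

Compound 3 `COc1cccc(/C=C/COC(=O)C2=C(C(OC)OC)NC(C)=C(C(=O)O)C2c2cccc(Cl)c2)c1` differs from compound 2 by 3-methoxyphenyl in place of 2-methoxyphenyl on a double-bonded chain carbon bound to a double-bonded chain carbon. For the measured compounds named here, no measured pair shows a methoxy group moved to another ring position, so the step from compound 1 to compound 2 bears on it only indirectly: it shows that this ring tolerates a change of substituent within a modest range. Compound 3 is therefore expected to land close to compound 2, with a step of a 1.5-fold lower number from compound 2 to compound 3 (0.17 log units; within the scatter) in this assay that may well stay within the scatter. The estimate for compound 3 is 4000 nM, between 1500 nM and 12000 nM.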

Compound 3, half-maximal inhibitory concentration: 4400 nM
Compound 3: middle estimate off by 1.1-fold (0.04 log units), on the low side; low and high end bracket the measured number.
By their numbers in this assay, from the lowest: compound 1; then compounds 3 and 2 (each within the scatter of the next).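

In this assay, among the compounds shown here, moving the methoxy group gives a 1.3-fold lower number from compound 2 to compound 3 (0.13 log units; within the scatter) and so offers the first direct comparison of two methoxy placements on this ring, which this pair does not separate. Replacing the 4-fluorophenyl of compound 1 with 3-methoxyphenyl gives a 2.2-fold higher number from compound 1 to compound 3 (0.34 log units; beyond the scatter) and so joins the earlier step to 2-methoxyphenyl: both methoxyphenyl compounds shown carry modestly higher numbers than compound 1. No measurement shown here accounts for these differences.

Compound 1 differs from compound 2 and compound 3 in both the ring substituent and its ring position, so the compounds shown cannot tell which of the two matters. A 4-methoxyphenyl or a 3-fluorophenyl at this place would pull those two changes apart, while an unsubstituted phenyl would show how either substituent compares with none.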